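This account rests on a few compounds, and the source may have more. Where it says the series, first, only, none or still open, it means among the compounds named here.

In a functional assay on Lu1 cells (Homo sapiens) for cytotoxicity, read by colorimetric assay and neutral red uptake, with a stated time of 72 h (a lower number here means a stronger inhibitor, a higher number a weaker inhibitor), the measured compounds are:
compound 1 `CO[C@@H](C(=O)N[C@@H]1CC[C@H](O)CNC1=O)[C@H](O)[C@@H](O)[C@H](O)/C=C/C(C)(C)C`, 36300 nM;
compound 2 `CO[C@@H](C(=O)N[C@@H]1CCCCNC1=O)[C@H](O)[C@@H](O)[C@H](O)/C=C/C(C)(C)C`, 500 nM.
Compound 3 `CO[C@@H](C(=O)N[C@@H]1CCCCNC1=O)[C@@H]1OC(C)(C)O[C@H](/C=C/C(C)(C)C)[C@@H]1O` gives > 150000 nM, which is a limit of the assay rather than a number.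

Compound 2 has the lowest number among those shown; the nearest number belongs to compound 1, and the step of a 73-fold lower number from compound 1 to compound 2 (1.86 log units; beyond the scatter) shows that replacing the hydroxy on the saturated ring carbon with hydrogen moved the number a long way toward stronger inhibition. Compound 4 `CO[C@@H](C(=O)N[C@H]1CC[C@H](O)CNC1=O)[C@H](O)[C@@H](O)[C@H](O)/C=C/C(C)(C)C` is not yet measured. It differs from compound 2 by 6-hydroxy-2-oxoazepan-3-yl in place of 2-oxoazepan-3-yl on an amide-type nitrogen. This puts a hydroxy back on the ring, and compound 1, which also carries that hydroxy, sits at 36300 nM. The number for compound 4 is therefore expected to rise by a similar amount, with a 50-fold higher number from compound 2 to compound 4 (1.70 log units; beyond the scatter). Compound 4 is estimated at 25000 nM, within 4000 nM to 150000 nM.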

Compound 4, half-maximal inhibitory concentration: 10000 nM
Estimate against measurement, compound 4: 2.5-fold (0.40 log units) above, within the range that was stated.
By their numbers in this assay, from the lowest: compound 2; then compound 4; then compound 1. At a limit, above all of these: compound 3.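

With the 6-hydroxy-2-oxoazepan-3-yl group in a second drawn configuration, the large cost of the hydroxy remains, with a 20-fold higher number from compound 2 to compound 4 (1.30 log units; beyond the scatter). Configuration also counts, though only modestly, with a 3.6-fold lower number from compound 1 to compound 4 (0.56 log units; beyond the scatter), and this comparison isolates it: the fact that compounds 1 and 4 differ only in the configuration as drawn. Both hydroxy compounds therefore stay well above compound 2 in this assay, whichever way the ring carbon is drawn.

As far as these compounds go, how much configuration matters without the hydroxy stays open, as compound 2 has no mirror-drawn partner here. From the compounds shown here alone, whether an amine or a carboxylic acid on the ring would behave like the hydroxy also stays open.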